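The source may report more compounds than this note shows. Statements on the series, on what has been measured and on what is new or still open speak of the compounds shown alone.

Notes on the aryl group carried by the ring nitrogen of the shared core.

Compound 1 `O=C1Nc2ccc(Cl)cc2/C1=N/NC(=S)N1CCN(c2ccccc2)CC1` in a functional assay on MCF7 cells (Homo sapiens) for inhibition, read by MTT assay, with a stated time of 72 h (a higher number here means a weaker inhibitor, a lower number a stronger inhibitor), gives 10400 nM. Compound 2 `Cc1ccc(N2CCN(C(=S)N/N=C3\C(=O)Nc4ccc(Cl)cc43)CC2)cc1` in this assay gives 17100 nM. Compound 3 `Cc1ccc(N2CCN(C(=S)N/N=C3\C(=O)Nc4ccc(Cl)cc43)CC2)c(C)c1` in this assay gives 10800 nM. On these three numbers compound 3 sits within the scatter of both neighbours: a 1.0-fold higher number from compound 1 to compound 3 (0.02 log units; within the scatter), and a 1.6-fold lower number from compound 2 to compound 3 (0.20 log units; within the scatter). The full spread of the set is a 1.6-fold higher number from compound 1 to compound 2 (0.22 log units; within the scatter), so nothing in the measured series separates from the rest.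

Compound 4 `O=C1Nc2ccc(Cl)cc2/C1=N/NC(=S)N1CCN(c2ccc(Cl)c(Cl)c2)CC1` differs from compound 3 at one place: 3,4-dichlorophenyl in place of 2,4-dimethylphenyl on an amine nitrogen in a ring.

Within the data shown here, the steps that bear on this change are those that alter the same aryl group. Exchanging phenyl for 2,4-dimethylphenyl gave a 1.0-fold higher number from compound 1 to compound 3 (0.02 log units; within the scatter); adding a single methyl on an aromatic carbon gave a 1.6-fold higher number from compound 1 to compound 2 (0.22 log units; within the scatter), and the second methyl gave a 1.6-fold lower number from compound 2 to compound 3 (0.20 log units; within the scatter). All stayed within the scatter. Among the measured compounds shown here, no measured step introduces chlorine on this ring, so a step of the same small size is the only thing the data support. The step is therefore expected to be a 1.0-fold higher number from compound 3 to compound 4 (0.01 log units; within the scatter), with no movement beyond the scatter in either direction. For compound 4 the expected value in this assay is 11000 nM, with a range from 4000 nM to 30000 nM.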

Compound 4, half-maximal inhibitory concentration: 10800 nM
Compound 4: the middle estimate sits 1.0-fold (0.01 log units) above what was measured; low and high end bracket the measured number.
By their numbers in this assay, from the lowest: compounds 1, 3, 4 and 2 (each within the scatter of the next).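

In this assay the first chlorine-bearing aryl group behaves like the methyl-bearing ones: 3,4-dichlorophenyl in place of 2,4-dimethylphenyl gives no change at the digits printed from compound 3 to compound 4 (within the scatter) even though the carbon-only substituents have given way to chlorine on a group of the same heavy-atom count. The same reading holds against the other two aryl groups, since replacing 4-methylphenyl gives a step within the scatter (a 1.6-fold lower number from compound 2 to compound 4 (0.20 log units; within the scatter)) and replacing phenyl does too (a 1.0-fold higher number from compound 1 to compound 4 (0.02 log units; within the scatter)). The position on the amine nitrogen of the six-membered ring has now taken unsubstituted, methyl-bearing and chlorine-bearing phenyl groups with no separation among the four compounds, and no measurement offers an account of this flat result.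

The compounds shown carry only methyl or chlorine on this aryl group, so it stays open whether a carboxylic acid or an amine on the ring, or a longer chain in place of the ring, would move the number beyond the scatter. The chlorine on the shared core is also constant throughout, which leaves the effect of changing that part of the molecule open as well.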